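Ethyl to methoxy on the pendant phenyl of two cores

The source may hold more compounds than are shown below. What is called first, only, known or untested is meant among the compounds shown, and "the series" means these compounds.

Compound 1 `COc1ccc(-c2ccc(C(=O)Nc3ccc(Oc4ccnc5[nH]ccc45)cc3)nc2)cc1` and compound 2 `CCc1ccc(-c2ccc(C(=O)Nc3ccc(Oc4ccnc5[nH]ccc45)cc3)nc2)cc1` share one core; compound 3 `CCc1ccc(-c2ccnc(C(=O)Nc3ccc(Oc4ccnc5[nH]ccc45)c(F)c3)c2)cc1` and compound 4 `COc1ccc(-c2ccnc(C(=O)Nc3ccc(Oc4ccnc5[nH]ccc45)c(F)c3)c2)cc1` share another, and the difference between the two cores is not broken down here. In a functional assay on PC-3 cells (Homo sapiens) for cytotoxicity, read by MTT assay, with a stated time of 72 h (a lower number here means a stronger inhibitor, a higher number a weaker inhibitor), compound 2 gives only a limit, > 10000 nM. Compound 1 likewise gives a limit, > 10000 nM. The change methoxy in place of ethyl on an aromatic carbon thus yields a step that the two limits leave unreadable from compound 2 to compound 1, both ends sitting at the limit of > 10000 nM in this assay, at which 2 of the 3 values shown sit. For the measured compounds named here, compound 3 gives 2960 nM in this assay, the only full number in the set. The change from compound 3 to compound 4 is methoxy in place of ethyl on an aromatic carbon, the same change as from compound 2 to compound 1. No size is read from the measured instance, so the step is expected to be small, a 1.4-fold higher number from compound 3 to compound 4 (0.13 log units; within the scatter). Compound 4 is expected to give about 4000 nM, between 1500 nM and 12000 nM.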

Compound 4, half-maximal inhibitory concentration: 20 nM
The estimate for compound 4 lay 200-fold (2.30 log units) above the measured number; the measured number lies below the stated range.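

In this assay, methoxy in place of ethyl on an aromatic carbon gives a 150-fold lower number from compound 3 to compound 4 (2.17 log units; beyond the scatter) on the core shared by compound 3 and compound 4. On the core shared by compound 1 and compound 2, the same change cannot be read, since both compounds give a limit and not a number: the limit of > 10000 nM in this assay, at which 2 of the 4 values shown sit. For the compounds shown here, the change can therefore be large on one core, but with only one readable instance, nothing shows whether the step carries over to the other core.

On these data alone, how an amine, a carboxylic acid or a longer alkoxy chain in place of the methoxy would read on the core of compound 4 remains open. Also open, as far as these compounds go, is which part of the difference between the two cores matters for this step.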